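Amide nitrogen substitution on the pyrazole-acid series

A few compounds are considered here, and "the series" means these few. Any claim that something is new, unique, unknown or untested is made for them only; others in the source may bear on it.

Of the compounds shown here, three of the shared core have been measured in an assay on microsomes from liver for inhibition of 3-hydroxy-3-methylglutaryl-coenzyme A reductase (Rattus norvegicus); a lower number here means a stronger inhibitor, a higher number a weaker inhibitor. Compound 1 `Cc1ccc(CN(C)C(=O)c2nn(-c3ccc(F)cc3)c(OC[C@@H](O)C[C@@H](O)CC(=O)O)c2C(C)C)cc1` gives 37 nM. Compound 2 `CC(C)c1c(C(=O)NCc2cccc(Cl)c2)nn(-c2ccc(F)cc2)c1OC[C@@H](O)C[C@@H](O)CC(=O)O` gives 5.4 nM, and compound 3 `CC(C)c1c(C(=O)NCc2ccccc2Cl)nn(-c2ccc(F)cc2)c1OC[C@@H](O)C[C@@H](O)CC(=O)O` gives 9.5 nM. Compound 3 thus stands second of the three numbers; one of its steps lies within the scatter (a 1.8-fold higher number from compound 2 to compound 3 (0.25 log units; within the scatter)) and the other clearly beyond it (a 3.9-fold lower number from compound 1 to compound 3 (0.59 log units; beyond the scatter)).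

Compound 4 `CC(C)c1c(C(=O)N(C)Cc2ccc(F)cc2)nn(-c2ccc(F)cc2)c1OC[C@@H](O)C[C@@H](O)CC(=O)O` differs from compound 3 by (4-fluorobenzyl)(methyl)amino in place of (2-chlorobenzyl)amino on a carbonyl carbon. The change removes the amide hydrogen and brings back a methyl on the amide nitrogen, as in compound 1. The two steps that bear on it both run from compound 1 to a secondary amide: a 6.9-fold lower number from compound 1 to compound 2 (0.84 log units; beyond the scatter) and a 3.9-fold lower number from compound 1 to compound 3 (0.59 log units; beyond the scatter). Going the other way, a rise in this assay of a similar size is expected, while the move of the halogen to the 4-position is not resolved here, since only the within-scatter a 1.8-fold higher number from compound 2 to compound 3 (0.25 log units; within the scatter) compares ring positions. Compound 4 is therefore expected to give 30 nM, within 10 nM to 90 nM. That estimate corresponds to a 3.2-fold higher number from compound 3 to compound 4 (0.50 log units; beyond the scatter).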

Compound 4, half-maximal inhibitory concentration: 18 nM
Beside the measured number, compound 4's estimate is 1.7-fold (0.22 log units) above it; the measured number falls inside the stated range.
By their numbers in this assay, from the lowest: compounds 2, 3 and 4 (each within the scatter of the next, the first and the last beyond it); then compound 1.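

In this assay, the tertiary amide is not tied to the weakest number: a 1.9-fold higher number from compound 3 to compound 4 (0.28 log units; within the scatter), although a 3.3-fold higher number from compound 2 to compound 4 (0.52 log units; beyond the scatter) remains. Going by these compounds alone, with the methyl on the amide nitrogen retained, a 2.1-fold lower number from compound 1 to compound 4 (0.31 log units; beyond the scatter) shows that the substituent on the benzyl ring also affects the number, a change that the earlier compounds did not isolate. No measurement here offers an explanation for these steps.

Compound 2 and compound 3 each differ from compound 4 in both the amide hydrogen and the ring halogen, so the contribution of the methyl alone remains unresolved. Also open, from the compounds shown here alone, is how an ethyl group on the amide nitrogen, or a longer chain carrying the aromatic ring, would behave.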